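The source may hold more compounds than are shown below. What is called first, only, known or untested is meant among the compounds shown, and "the series" means these compounds.

Values from a functional assay on A549 cells (Homo sapiens) for inhibition, read by sulforhodamine B assay, with a stated time of 72 h (a lower number here means a stronger inhibitor of growth, a higher number a weaker inhibitor of growth), are as follows:
compound 1 `CNC(=O)/C=C/c1ccncc1-c1ccc2ccccc2c1` gives 6620 nM
compound 2 `CNC(=O)CCc1ccncc1-c1ccc2ccccc2c1` gives 10400 nM
compound 3 `O=C(/C=C/c1ccncc1-c1ccc2ccccc2c1)N1CCOCC1` gives 8410 nM

Compound 3 lies within the scatter of both other compounds, so the three numbers set no order among them. Compound 4 `NC(=O)/C=C/c1ccncc1-c1ccc2ccccc2c1` differs from compound 3 by amino in place of morpholin-4-yl on a carbonyl carbon. The closest evidence is the exchange on that same carbonyl carbon (a 1.3-fold higher number from compound 1 to compound 3 (0.10 log units; within the scatter)), which stays within the scatter. The change in the chain (a 1.6-fold higher number from compound 1 to compound 2 (0.20 log units; within the scatter)) lies elsewhere and also stays within the scatter. No step beyond the scatter is therefore expected in this assay, and the expected step is small (a 1.2-fold lower number from compound 3 to compound 4 (0.08 log units; within the scatter)). The estimate for compound 4 is 7000 nM as a middle value, expected between 3000 nM and 14000 nM in repeated measurements.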

Compound 4, concentration for 50% growth inhibition: > 10000 nM
Compound 4: a limit, no number (the forecaster's own chance of this, stated with the estimate: 5%); middle value at least 1.4-fold (0.15 log units) away from the limit.
By their numbers in this assay, from the lowest: compounds 1, 3 and 2 (each within the scatter of the next).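

In this assay compound 4 gives > 10000 nM, which is a limit of the assay and not a number. Its floors, an at least 1.1-fold higher number from compound 3 to compound 4 (0.07 log units; that floor lies within the scatter) and an at least 1.5-fold higher number from compound 1 to compound 4 (0.17 log units; that floor lies within the scatter), show no change beyond the scatter on this carbonyl carbon, although the exchange leaves carbamoyl in place of larger or methylated amides, and the step from compound 2 to compound 4 cannot be read. Compound 4 alone carries such a limit: the limit of > 10000 nM in this assay, at which 1 of the 4 values shown sits.

On these data alone, how far compound 4 lies past its limit stays open. Also open, as far as these compounds go, is what a carboxylic acid or a piperazine on this carbonyl carbon would give.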